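Methoxy for fluoro on the anilino ring of compound 2

This account rests on a few compounds, and the source may have more. Where it says the series, first, only, none or still open, it means among the compounds named here.

Measured compounds in a functional assay on HT-29 cells (Homo sapiens) for antiproliferative activity, read by MTT assay, with a stated time of 48 h; on this read-out lower numbers stand for stronger inhibition and higher numbers for weaker inhibition:
Compound 1, `COc1ccc(N/C=C\C(=O)c2cn(-c3ccccc3)nc2-c2ccc(F)cc2)cc1`, gives 3200 nM.
Compound 2, `COc1cc(-c2nn(-c3ccccc3)cc2C(=O)/C=C\Nc2ccc(F)cc2)cc(OC)c1OC`, gives 12500 nM.

Of these two numbers, compound 2 has the higher one in this assay, and the gap to compound 1 lies beyond the usual scatter. Compound 3, `COc1ccc(N/C=C\C(=O)c2cn(-c3ccccc3)nc2-c2cc(OC)c(OC)c(OC)c2)cc1`, differs from compound 2 in one place: methoxy in place of fluoro on an aromatic carbon. Within the data shown here, no measured pair separates this change on its own, so its effect is uncertain. A modest move toward a lower number is expected, about the scatter in size, with the step from compound 2 to compound 3 estimated at a 1.6-fold lower number from compound 2 to compound 3 (0.19 log units; within the scatter). Compound 3 is therefore expected to give 8000 nM, within a range of 3000 nM to 20000 nM.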

Compound 3, half-maximal inhibitory concentration: 5780 nM
Compound 3: the middle estimate sits 1.4-fold (0.14 log units) above what was measured, and the stated range covers the measured number.
By their numbers in this assay, from the lowest: compounds 1 and 3 (each within the scatter of the next); then compound 2.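

In this assay, among these compounds, methoxy in place of fluoro on this ring gives a 2.2-fold lower number from compound 2 to compound 3 (0.33 log units; beyond the scatter), the first reading of this change on its own, and a modest one. With the (4-methoxyphenyl)amino group kept, 3,4,5-trimethoxyphenyl in place of 4-fluorophenyl gives a 1.8-fold higher number from compound 1 to compound 3 (0.26 log units; within the scatter), so these two compounds cannot be told apart. Nothing measured here gives a reason for either step. Open questions are how an amine or a carboxylic acid would read at this position, and whether the methoxy step holds with other groups on the shared core.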